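The source may report more compounds than this note shows. Statements on the series, on what has been measured and on what is new or still open speak of the compounds shown alone.

Series notes. Within the data shown here, compound 1 `CS(=O)(=O)Nc1ccc(-n2cc(-c3ccccc3)nn2)cc1Oc1ccccc1` is the only member with a number in a functional assay on A549 cells (Homo sapiens) for inhibition, read by MTT assay, with a stated time of 48 h; a higher number here means a weaker inhibitor, a lower number a stronger inhibitor: in this assay compound 1 gives 29900 nM, so it stands as a weak inhibitor and, with nothing else measured, it cannot be placed relative to any other compound. Compound 2 `Cc1ccc(-c2cn(-c3ccc(NS(C)(=O)=O)c(Oc4ccccc4)c3)nn2)cc1` belongs to the same set, but in this assay compound 2 gives "not determined" (no result reported), so no result is reported for it. Compound 3 `CS(=O)(=O)Nc1ccc(-n2cc(COc3ccc([N+](=O)[O-])cc3)nn2)cc1Oc1ccccc1` is not yet measured. It differs from compound 1 at one place: (4-nitrophenoxy)methyl in place of phenyl on an aromatic carbon. Among the measured compounds shown here, no step between two measured compounds is available, so the size of the step in this assay can only be expected, not read off. The working expectation is a step from compound 1 to compound 3 of a 1.2-fold lower number from compound 1 to compound 3 (0.08 log units; within the scatter), which is no larger than the scatter and has no firm direction. On that basis compound 3 is estimated in this assay at 25000 nM, within a range of 6000 nM to 90000 nM.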

Compound 3, half-maximal inhibitory concentration: 6600 nM
Compound 3: middle estimate off by 3.8-fold (0.58 log units), on the high side; the range from low to high includes it.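

Among these compounds, the aromatic carbon of the five-membered aromatic ring with 3 nitrogen tolerates a larger group than phenyl in this assay, since (4-nitrophenoxy)methyl in place of phenyl gives a 4.5-fold lower number from compound 1 to compound 3 (0.66 log units; beyond the scatter), the first step that can be read. This single step changes several things at once, keeping one six-membered aromatic ring of carbon only while adding an oxygen-linked methylene and a nitro group, and it brings in hydrogen-bond acceptors where phenyl has none, so it cannot be assigned to any one of these parts. No evidence at hand accounts for the lower number. Going by these compounds, whether the nitro group or the oxygen-linked methylene carries the step remains open, and a plain benzyl or unsubstituted phenoxymethyl group at this carbon would separate the two. Also open, on these data alone, is whether an amine or a carboxylic acid in place of the nitro group would keep the lower number.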